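From Cyclopropyl to Cyclobutyl: What Compound 4 Should Show

The source may hold more compounds than are shown below. What is called first, only, known or untested is meant among the compounds shown, and "the series" means these compounds.

Measured in an assay on membranes from HEK293 cells for displacement of a labelled ligand from adenosine receptor A2b (Homo sapiens), read by scintillation counting, with a stated time of 30 min; a higher number here means a weaker inhibitor, a lower number a stronger inhibitor:
compound 1, `CC1=C(C(=O)OCC(C)C)C(c2ccoc2)NC(=O)N1`, gives 326 nM
compound 2, `CC1=C(C(=O)CC(C)C)C(c2ccoc2)NC(=O)N1`, gives 1010 nM
compound 3, `CC1=C(C(=O)OCC2CC2)C(c2ccoc2)NC(=O)N1`, gives 426 nM

Among these three numbers compound 3 stands second highest in this assay. Its nearest neighbour is compound 1: the step of a 1.3-fold higher number from compound 1 to compound 3 (0.12 log units; within the scatter) lies within the scatter, so the two cannot be ordered. Its furthest neighbour is compound 2, reached through a 2.4-fold lower number from compound 2 to compound 3 (0.37 log units; beyond the scatter), a modest step beyond the scatter.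

Compound 4, `CC1=C(C(=O)OCC2CCC2)C(c2ccoc2)NC(=O)N1`, differs from compound 3 in one place: cyclobutyl in place of cyclopropyl on a saturated chain carbon bound to an oxygen next to a carbonyl group. The step that bears most directly on this change is the one at the same place, a 1.3-fold higher number from compound 1 to compound 3 (0.12 log units; within the scatter), which exchanged one small alkyl group for another and stayed within the scatter. The steps of a 3.1-fold higher number from compound 1 to compound 2 (0.49 log units; beyond the scatter) and a 2.4-fold lower number from compound 2 to compound 3 (0.37 log units; beyond the scatter) concern a change on the carbonyl carbon, a different place, and so carry little weight here.

Compound 4 is therefore expected to sit close to compound 3 in this assay, with the step of a 1.0-fold lower number from compound 3 to compound 4 (0.01 log units; within the scatter) not expected to exceed the scatter. For compound 4 the estimate is 420 nM, within a range from 180 nM to 950 nM.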

Compound 4, inhibition constant: 739 nM
Compound 4: the middle estimate sits 1.8-fold (0.25 log units) below what was measured; low and high end bracket the measured number.
By their numbers in this assay, from the lowest: compounds 1, 3, 4 and 2 (each within the scatter of the next, the first and the last beyond it).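

In this assay, the exchange of cyclopropyl for cyclobutyl on a saturated chain carbon bound to an oxygen next to a carbonyl group stays within the scatter (a 1.7-fold higher number from compound 3 to compound 4 (0.24 log units; within the scatter)), yet it gives this position its first step beyond the scatter among the alkyl groups compared there, a modest one (a 2.3-fold higher number from compound 1 to compound 4 (0.36 log units; beyond the scatter)), where isopropyl and cyclopropyl could not be ordered. The separation that cyclopropylmethoxy had from isobutyl on a carbonyl carbon (a 2.4-fold lower number from compound 2 to compound 3 (0.37 log units; beyond the scatter)) is not kept by cyclobutylmethoxy (a 1.4-fold lower number from compound 2 to compound 4 (0.14 log units; within the scatter)), so the two esters with a ring in this chain do not behave as one group against compound 2, although they cannot be ordered against each other. Nothing among the data shown explains these differences.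

The compounds shown leave open whether cyclopentyl or a longer chain in the same place would move further from compound 1 or fall back within the scatter of it. They also leave open what an amine or a carboxylic acid on this chain would do in this assay when the rest of the core of compound 1 is kept unchanged.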